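Chromone Schiff bases: imine to hydrazone at the double-bonded nitrogen

The compounds below may be only part of what the source reports. "The series", "measured", "known", "first", "only" and "open" are said of these compounds alone.

Measured so far:
compound 1 `O=c1cc(/C=N\c2ccccc2O)c2c(OCc3ccccc3)cc(OCc3ccccc3)cc2o1` — 348000 nM
compound 2 `O=c1cc(/C=N\c2ccc(O)cc2)c2c(OCc3ccccc3)cc(OCc3ccccc3)cc2o1` — 107000 nM

Among the compounds with values here, in a functional assay, read by spectrophotometry, with a stated time of 1 h (on this read-out lower numbers stand for stronger inhibition and higher numbers for weaker inhibition), compound 2 gives the lowest of the two numbers; the only other measured compound, compound 1, sits higher by a 3.3-fold lower number from compound 1 to compound 2 (0.51 log units; beyond the scatter), and that step came from placing 4-hydroxyphenyl in place of 2-hydroxyphenyl on the double-bonded nitrogen.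

Compound 3 `O=c1cc(/C=N\Nc2ccc([N+](=O)[O-])cc2)c2c(OCc3ccccc3)cc(OCc3ccccc3)cc2o1` follows from compound 2 by (4-nitrophenyl)amino in place of 4-hydroxyphenyl on a double-bonded nitrogen. Within the data shown here, no measured step bears on this change: the single step in hand, from compound 1 to compound 2, only moves the hydroxy group about the same ring, and nothing measured speaks to replacing the ring itself with a (4-nitrophenyl)amino group. The direction of the step in this assay is therefore open, and any expectation must be wide.

Compound 3 is expected to come in near compound 2, at 120000 nM with a range of 25000 nM to 600000 nM, an expected step of a 1.1-fold higher number from compound 2 to compound 3 (0.05 log units; within the scatter).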

Compound 3, half-maximal inhibitory concentration: 97900 nM
The estimate for compound 3 lay 1.2-fold (0.09 log units) above the measured number, within the range that was stated.
By their numbers in this assay, from the lowest: compounds 3 and 2 (each within the scatter of the next); then compound 1.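

In this assay the place on the double-bonded nitrogen accepts a (4-nitrophenyl)amino group: a 1.1-fold lower number from compound 2 to compound 3 (0.04 log units; within the scatter) is the reading for its exchange with 4-hydroxyphenyl, so a change of the whole substituent, with an added nitrogen in the link, leaves compound 3 level with compound 2. Measured against 2-hydroxyphenyl, the same group gives a 3.6-fold lower number from compound 1 to compound 3 (0.55 log units; beyond the scatter) as its step, which leaves compound 1 apart from the other two and shows that this position is not tied to a hydroxy group on the ring. Nothing available explains this tolerance.

Still open, on these data alone, is what the nitro group itself contributes, which a carboxylic acid or a plain amine on the ring in its place would test. Also open, as far as these compounds go, is whether the ring is needed at all, which a short alkyl chain on the double-bonded nitrogen would address.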